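Shifting the ether-linked aryl group in a translocator protein series

The source may hold more compounds than are shown below. What is called first, only, known or untested is meant among the compounds shown, and "the series" means these compounds.

Of the compounds shown here, two sharing one core have been measured in an assay on isolated protein (kidney, strain Wistar) for displacement of a labelled ligand from Translocator protein (Rattus norvegicus), read by scintillation counting, with a stated time of 90 min; on this read-out lower numbers stand for stronger inhibition and higher numbers for weaker inhibition. Compound 1 `CCN(CC)C(=O)Cc1c(-c2ccc(OCc3cccc(F)c3)cc2)nn2c(C)cc(C)nc12` gives 0.47 nM, and compound 2 `CCN(CC)C(=O)Cc1c(-c2ccc(OCc3ccc(C(F)(F)F)cc3)cc2)nn2c(C)cc(C)nc12` gives 1.6 nM. Among the measured compounds shown here, compound 2 therefore stands at the higher of the two numbers, the one step recorded being a 3.4-fold higher number from compound 1 to compound 2 (0.53 log units; beyond the scatter). Compound 3 `CCN(CC)C(=O)Cc1c(-c2ccc(OCCc3ccccc3)cc2)nn2c(C)cc(C)nc12` differs from compound 2 by benzyl in place of 4-(trifluoromethyl)phenyl on a saturated chain carbon bound to an oxygen on an aromatic ring. For the measured compounds named here, only that single step bears on this change, and it concerned exchange of one aryl group for another at the same place, whereas here the trifluoromethyl is lost and a further chain carbon is inserted; the two changes are not the same, so the guidance is partial. For compound 3 in this assay, the expected step is a 1.6-fold lower number from compound 2 to compound 3 (0.20 log units; within the scatter), a modest move back toward a lower number, with wide uncertainty. The estimate for compound 3 is 1 nM, within the range 0.3 nM to 4 nM.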

Compound 3, inhibition constant: 0.13 nM
The estimate for compound 3 lay 7.7-fold (0.89 log units) above the measured number; the measured number lies below the stated range.
By their numbers in this assay, from the lowest: compound 3; then compound 1; then compound 2.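

In this assay, replacing the 4-(trifluoromethyl)benzyl group on the oxygen with phenethyl gives a 12-fold lower number from compound 2 to compound 3 (1.09 log units; beyond the scatter), the largest step seen so far, and the same group also outdoes the 3-fluorobenzyl group of compound 1, with a 3.6-fold lower number from compound 1 to compound 3 (0.56 log units; beyond the scatter). Among these three compounds, then, the position accepts a longer chain to the aromatic ring, and the lowest number comes from a ring carrying neither fluorine nor trifluoromethyl. Nothing at hand explains why phenethyl gives the lowest number.

The step from compound 2 to compound 3 removes the trifluoromethyl and lengthens the chain together, so the compounds shown cannot separate the contribution of each change. Going by these compounds, whether a longer chain such as 3-phenylpropyl, or an amine on the chain, would keep the number this low also remains open.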